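The source may hold more compounds than are shown below. What is called first, only, known or untested is meant among the compounds shown, and "the series" means these compounds.

Measured compounds:
compound 1 `CCCCc1cn(-c2ccc(NC(=O)Nc3cc(CCC(C)=O)ccc3C)cc2)nn1` — 2490 nM
compound 3 `CCOP(=O)(OCC)OCCc1cn(-c2ccc(NC(=O)Nc3ccccc3C)cc2)nn1` — 890 nM
compound 2 `O=C(O)CCc1cn(-c2ccc(NC(=O)Nc3ccccc3C(F)(F)F)cc2)nn1` — "not determined" (no result reported)

In an assay on isolated protein for inhibition of ATP-dependent RNA helicase DDX3X (Homo sapiens), read by FRET, with stated times of 30 s and 40 min (a lower number here means a stronger inhibitor, a higher number a weaker inhibitor), compound 1 gives 2490 nM, the higher of the two numbers reported; the nearest is compound 3, whose value in this assay, 890 nM, sits lower by a gap beyond the usual scatter. Compound 2 has no result in this assay. Compound 4 `CCCCc1cn(-c2ccc(NC(=O)Nc3cc(OC4CCCC4)ccc3C)cc2)nn1` differs from compound 1 by cyclopentyloxy in place of 2-acetylethyl on an aromatic carbon. Going by the values given here, no step between measured compounds covers this exchange, so the direction rests on judgement alone; a small step is expected, likely within the scatter, with a slight lean toward a lower number. Compound 4 is therefore estimated at 1500 nM, within 500 nM to 5000 nM, a step of a 1.7-fold lower number from compound 1 to compound 4 (0.22 log units; within the scatter).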

Compound 4, half-maximal inhibitory concentration: 140 nM
The estimate for compound 4 lay 11-fold (1.03 log units) above the measured number, and the stated range ends above it.
By their numbers in this assay, from the lowest: compound 4; then compound 3; then compound 1.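

In this assay the position meta to a large group and para to a methyl group proves sensitive to its substituent: cyclopentyloxy in place of 2-acetylethyl gives an 18-fold lower number from compound 1 to compound 4 (1.25 log units; beyond the scatter) on the core of compound 1. Both groups count one hydrogen-bond acceptor and no donor, so that count does not separate them. No measurement shown here accounts for the step.

From the compounds shown here alone, it remains open whether the ring or the oxygen on the aromatic carbon matters more, and how an open-chain butoxy group or an amine would read at this position.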